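A few compounds are considered here, and "the series" means these few. Any claim that something is new, unique, unknown or untested is made for them only; others in the source may bear on it.

Measured compounds and their values:

Compound 1 `C=CC[C@H]1C[C@]2([C@@H](C)Cc3ccc(OC)cc3)OCOC2=CC1=O`: 20 nM
Compound 2 `C=CC[C@H]1C[C@]2([C@@H](C)Cc3ccc(OC)c(C)c3)OCOC2=CC1=O`: 410 nM
Compound 3 `C=CC[C@H]1C[C@]2([C@@H](C)Cc3ccc(OC)c(C(N)=O)c3)OCOC2=CC1=O`: 12 nM

In a functional assay on M14 cells (Homo sapiens) for antiproliferative activity, with a stated time of 72 h (a lower number here means a stronger inhibitor, a higher number a weaker inhibitor), compound 1 stands second highest of the three numbers. Its nearest neighbour is compound 3, reached by the step of a 1.7-fold lower number from compound 1 to compound 3 (0.22 log units; within the scatter); the furthest is compound 2, reached by the step of a 21-fold higher number from compound 1 to compound 2 (1.31 log units; beyond the scatter), which also sets compound 2 apart from compound 3 by a 34-fold lower number from compound 2 to compound 3 (1.53 log units; beyond the scatter).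

Compound 4 `C=CC[C@H]1C[C@]2([C@@H](C)Cc3ccc(OC)nc3)OCOC2=CC1=O` is not yet measured. It differs from compound 1 by 6-methoxypyridin-3-yl in place of 4-methoxyphenyl on a saturated chain carbon, two bonds along the chain from a saturated ring carbon.

Within the data shown here, none of the measured steps changes a ring atom; the two that touch the aromatic ring add a group to it. Of these, the methyl step from compound 1 to compound 2 was large and the carbamoyl step from compound 1 to compound 3 stayed within the scatter, so additions to this ring have gone either way. The swap to 6-methoxypyridin-3-yl is a different kind of change, and the data give no direct guide. Compound 4 is therefore expected to land near compound 1 in this assay, with a step of a 2.0-fold higher number from compound 1 to compound 4 (0.30 log units; within the scatter), most likely within the scatter. The estimate for compound 4 is 40 nM, in the range 10 nM to 160 nM.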

Compound 4, half-maximal inhibitory concentration: 180 nM
Beside the measured number, compound 4's estimate is 4.5-fold (0.65 log units) below it, and the stated range ends below it.
By their numbers in this assay, from the lowest: compounds 3 and 1 (each within the scatter of the next); then compound 4; then compound 2.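

In this assay, exchanging 4-methoxyphenyl for 6-methoxypyridin-3-yl gives a 9.0-fold higher number from compound 1 to compound 4 (0.95 log units; beyond the scatter), so replacing one ring carbon with nitrogen, with the methoxy group still in place, weakens compound 4 beyond the scatter. The earlier steps shown here only added a group to the benzene ring, whereas this one shows that the identity of an atom within the ring also affects the value, even though no substituent was added. No measurement bears on the reason for this loss.

The compounds shown leave open whether the carbamoyl group of compound 3 or the methyl group of compound 2 would have the same effect on the 6-methoxypyridin-3-yl ring. They also leave open how a pyrimidine or thiophene ring would fare in this place, and what an amine or hydroxyl group would do in place of the methoxy group.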